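Chloro scan on the aryl ring of the enaminone acids

The source may hold more compounds than are shown below. What is called first, only, known or untested is meant among the compounds shown, and "the series" means these compounds.

Measured so far:
compound 1 `COC(=O)C(=N)/C=C(\O)c1cccc(Br)c1` — 0%
compound 2 `N/C(=C\C(=O)c1ccccc1)C(=O)O` — 17%
compound 3 `N/C(=C\C(=O)c1ccccc1Cl)C(=O)O` — 19%

In an assay for inhibition of kynurenine 3-monooxygenase (Rattus norvegicus), tested at 10 uM (on this read-out higher numbers stand for more inhibition at the one concentration tested (going by the name of the read-out) and lower numbers for less inhibition), compound 2 stands second highest of the three numbers. Its nearest neighbour is compound 3, which gives 19%; the step of a number 2 percentage points higher from compound 2 to compound 3 (within the scatter) lies within the scatter. Furthest off is compound 1 with 0%, beyond the scatter below compound 2.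

The next compound, compound 4 `N/C(=C\C(=O)c1ccc(Cl)cc1)C(=O)O`, is not yet measured in this assay. It differs from compound 2 by chloro in place of hydrogen on an aromatic carbon, para to a group of 8 heavy atoms. Among the compounds with values here, the one measured step that bears on this, a number 2 percentage points higher from compound 2 to compound 3 (within the scatter), is also chloro in place of hydrogen on an aromatic carbon of the same ring and was within the scatter. Within the data shown here, no other step involves this ring.

On that basis a step of no more than the scatter is expected for compound 4, a number 2 percentage points higher from compound 2 to compound 4 (within the scatter). Compound 4 is estimated at 19%, with a range of 5% to 35%.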

Compound 4, a percentage reported as inhibition, at one concentration (the size of the read-out at that concentration, not a potency): 33%
Compound 4: the middle estimate sits 14 percentage points below what was measured, and the stated range covers the measured number.
By their numbers in this assay, from the lowest: compound 1; then compounds 2 and 3 (each within the scatter of the next); then compound 4.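

In this assay, within the data shown here, chloro in place of hydrogen on an aromatic carbon, para to a group of 8 heavy atoms, gives a number 16 percentage points higher from compound 2 to compound 4 (beyond the scatter) and so provides the first step on this ring beyond the scatter. The same exchange on the same ring gives a number 2 percentage points higher from compound 2 to compound 3 (within the scatter) and stays within the scatter, so across these two compounds the size of the step depends on where the chloro stands. No measurement at hand accounts for this difference between the two steps.

Going by these compounds, whether a different group at the position para to the group of 8 heavy atoms, such as fluoro, methoxy or an amine, would match chloro remains open. Also open, on these data alone, is whether the step would persist with an amide in place of the carboxylic acid.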